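The source may hold more compounds than are shown below. What is called first, only, known or untested is meant among the compounds shown, and "the series" means these compounds.

Measured compounds:
compound 1 `CCOC(=O)C(C(=O)OCC)C(CC(=O)C[C@@H]1O[C@H](CO)[C@@H](O)[C@H](O)[C@H]1O)c1cccnc1` — -20%
compound 2 `O=C(/C=C/c1ccc(Cl)cc1)C[C@@H]1O[C@H](CO)[C@@H](O)[C@H](O)[C@H]1O` — -5.97%

Within the data shown here, in an assay on isolated protein for inhibition of lysosomal alpha-glucosidase (Rattus norvegicus), tested at 100 uM (on this read-out higher numbers stand for more inhibition at the one concentration tested (going by the name of the read-out) and lower numbers for less inhibition), compound 1 gives -20%, the lowest of the two numbers known; compound 2, the nearest, gives -5.97%, a difference that lies beyond the usual scatter. Compound 3 `CCOC(=O)C(C(=O)OCC)C(CC(=O)C[C@@H]1O[C@H](CO)[C@@H](O)[C@H](O)[C@H]1O)c1ccc2ccccc2c1` has not yet been measured. It departs from compound 1 in one place: naphthalen-2-yl in place of pyridin-3-yl on a saturated chain carbon bound to two saturated chain carbons. Among the measured compounds shown here, with no comparable pair measured, the step of a number 12 percentage points higher from compound 1 to compound 3 (beyond the scatter) is an estimate, and a small rise not clearly beyond the scatter is expected. Compound 3 is therefore estimated at -8%, between -30% and 15%.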

Compound 3, a percentage reported as inhibition, at one concentration (the size of the read-out at that concentration, not a potency): -20%
The estimate for compound 3 lay 12 percentage points above the measured number, within the range that was stated.
By their numbers in this assay, from the lowest: compounds 1 and 3 (each within the scatter of the next); then compound 2.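

In this assay, naphthalen-2-yl in place of pyridin-3-yl on a saturated chain carbon bound to two saturated chain carbons gives no change at the digits printed from compound 1 to compound 3 (within the scatter). At this position, then, exchanging the single ring with its nitrogen for two six-membered aromatic rings of carbon only does not move the read-out. No supporting measurement offers an explanation for this result. As far as these compounds go, whether an amine or a carboxylic acid at this carbon would give a different reading remains open, and so does the effect of replacing the ethyl esters with carboxylic acids.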